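Removing one chloro from a dichlorinated purine-like core

A few compounds are considered here, and "the series" means these few. Any claim that something is new, unique, unknown or untested is made for them only; others in the source may bear on it.

Compound 1 `ClCc1ccc(Cn2cnc3nc(Cl)nc(Cl)c32)cc1` shows the lowest of the two numbers measured in a functional assay on 786-0 cells (Homo sapiens) for cytotoxicity, read by sulforhodamine B assay, with a stated time of 48 h; on this read-out higher numbers stand for weaker inhibition of growth and lower numbers for stronger inhibition of growth: compound 1 gives 3710 nM. Compound 2 `Nc1nc(Cl)c2ncn(Cc3ccccc3CCl)c2n1` differs in several places and gives 52500 nM in this assay, beyond the scatter. Compound 3 `ClCc1ccc(Cn2cnc3ncnc(Cl)c32)cc1` differs from compound 1 by a single change, hydrogen in place of chloro on an aromatic carbon. Among the measured compounds shown here, no single-change step between measured compounds guides this. The expected change from compound 1 to compound 3 in this assay is a modest rise, a 1.8-fold higher number from compound 1 to compound 3 (0.24 log units; within the scatter), probably near the edge of scatter. Compound 3 is estimated at 6500 nM, ranging from 2200 nM to 20000 nM.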

Compound 3, concentration for total growth inhibition: 3010 nM
The estimate for compound 3 lay 2.2-fold (0.33 log units) above the measured number; low and high end bracket the measured number.
By their numbers in this assay, from the lowest: compounds 3 and 1 (each within the scatter of the next); then compound 2.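

Hydrogen in place of chloro on the aromatic carbon between two ring nitrogen atoms gives a 1.2-fold lower number from compound 1 to compound 3 (0.09 log units; within the scatter) in this assay, so the chloro at this position can go without a change beyond the scatter on this read-out. The other chloro on that ring stays in both compounds, so this step speaks for one position only. Nothing at hand explains why the number holds.

As far as these compounds go, whether an amine, a methoxy group or a fluoro at this same carbon would keep the number in this range remains open. So does the effect of replacing the remaining ring chloro with hydrogen.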